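Homologating the Butylamide Chain on Compound 3

The source may hold more compounds than are shown below. What is called first, only, known or untested is meant among the compounds shown, and "the series" means these compounds.

Compound 3, `CCCCNC(=O)CCn1nnnc1[C@@H](COCc1ccccc1)NC(=O)C(C)(C)N`, holds the lower of the two numbers shown in an assay on isolated protein for displacement of a labelled ligand from growth hormone secretagogue receptor type 1 (Homo sapiens), with a stated time of 1 h (a higher number here means a weaker inhibitor, a lower number a stronger inhibitor), at 2190 nM. Compound 2, `CC(C)(N)C(=O)N[C@H](COCc1ccccc1)c1nnnn1CC#N`, gives 4170 nM, and the step of a 1.9-fold lower number from compound 2 to compound 3 (0.28 log units; within the scatter) lies within the scatter. For compound 1, `CC(C)(N)C(=O)N[C@H](COCc1ccccc1)c1nnnn1CCCCCNS(C)(=O)=O`, the result is only a limit, > 5000 nM. The step of an at least 2.2-fold lower number from compound 1 to compound 3 (0.35 log units; beyond the scatter) is at least modest. Compound 4, `CCCCNC(=O)CCCn1nnnc1[C@@H](COCc1ccccc1)NC(=O)C(C)(C)N`, differs from compound 3 by (butylcarbamoyl)methyl in place of butylcarbamoyl on a saturated chain carbon, two bonds along the chain from an aromatic nitrogen. Among the measured compounds shown here, no measured step matches this lengthening by one chain carbon; the nearest comparison, the step from compound 2 to compound 3, stayed within the scatter, so no change beyond the scatter is expected in this assay, in either direction. For compound 4 the estimate in this assay is 2000 nM (range 800 nM to 5000 nM), an expected step of a 1.1-fold lower number from compound 3 to compound 4 (0.04 log units; within the scatter).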

Compound 4, inhibition constant: 1780 nM
The estimate for compound 4 lay 1.1-fold (0.05 log units) above the measured number; low and high end bracket the measured number.
By their numbers in this assay, from the lowest: compounds 4, 3 and 2 (each within the scatter of the next, the first and the last beyond it). At a limit, above all of these: compound 1.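

In this assay, (butylcarbamoyl)methyl in place of butylcarbamoyl gave a 1.2-fold lower number from compound 3 to compound 4 (0.09 log units; within the scatter), so the added chain carbon left this position without a change that can be read. Against the cyano group, however, the longer chain now gave a 2.3-fold lower number from compound 2 to compound 4 (0.37 log units; beyond the scatter), a step beyond the scatter, where the shorter chain of compound 3 had stayed within it. A further step, an at least 2.8-fold lower number from compound 1 to compound 4 (0.44 log units; beyond the scatter), is only a floor, set by a limit: the limit of > 5000 nM in this assay, at which 1 of the 4 values shown sits.

From the compounds shown here alone, whether a still longer chain, or an amine or a carboxylic acid at the end of the chain, would take the number beyond the scatter from compound 4 stays open.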